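The source may hold more compounds than are shown below. What is called first, only, known or untested is meant among the compounds shown, and "the series" means these compounds.

Measured compounds in an assay on HEK293 cells for displacement of a labelled ligand from NPC1-like intracellular cholesterol transporter 1 (Homo sapiens); on this read-out higher numbers stand for weaker inhibition and lower numbers for stronger inhibition: compound 1 `CC(C)(C)OC(=O)NCCCNC(=O)CN1CN(c2ccccc2)C2(CCN(C(=O)c3ccc(C4CCCCC4)cc3)CC2)C1=O` gives 6000 nM; compound 2 `O=C(CN1CN(c2ccccc2)C2(CCN(C(=O)c3ccc(C4CCCCC4)cc3)CC2)C1=O)N1CCC(CO)CC1` gives 1100 nM; compound 3 `CC(C)(C)OC(=O)NCNC(=O)CN1CN(c2ccccc2)C2(CCN(C(=O)c3ccc(C4CCCCC4)cc3)CC2)C1=O` gives 1700 nM.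

Compound 3 stands second highest of the three; one of its gaps, a 1.5-fold higher number from compound 2 to compound 3 (0.19 log units; within the scatter), is within the scatter, the other, a 3.5-fold lower number from compound 1 to compound 3 (0.55 log units; beyond the scatter), is beyond it.

Compound 4 `CC1CCCN(C(=O)CN2CN(c3ccccc3)C3(CCN(C(=O)c4ccc(C5CCCCC5)cc4)CC3)C2=O)C1` differs from compound 3 by 3-methylpiperidin-1-yl in place of (((tert-butoxycarbonyl)amino)methyl)amino on a carbonyl carbon. Within the data shown here, the closest precedent is the step to a piperidinyl amide, a 5.5-fold lower number from compound 1 to compound 2 (0.74 log units; beyond the scatter), together with compound 2 sitting close to compound 3. Compound 4 is therefore expected to land near compound 2, i.e. a small lowering from compound 3 in this assay, a 1.7-fold lower number from compound 3 to compound 4 (0.23 log units; within the scatter), possibly within the scatter. Estimated value for compound 4: 1000 nM, range 400 nM to 2500 nM.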

Compound 4, half-maximal inhibitory concentration: 3600 nM
For compound 4 the middle estimate is 3.6-fold (0.56 log units) below the measured one, outside the stated range (above it).
By their numbers in this assay, from the lowest: compounds 2 and 3 (each within the scatter of the next); then compounds 4 and 1 (each within the scatter of the next).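

Placing a piperidine ring on this carbonyl carbon does not by itself keep the number low: 3-methylpiperidin-1-yl gives a 2.1-fold higher number from compound 3 to compound 4 (0.33 log units; beyond the scatter) and, against 4-(hydroxymethyl)piperidin-1-yl, a 3.3-fold higher number from compound 2 to compound 4 (0.51 log units; beyond the scatter) on the same amide. The ring and the open chain of compound 1 are not separated, with a 1.7-fold lower number from compound 1 to compound 4 (0.22 log units; within the scatter) within the scatter. Nothing available explains the gap between the two piperidine amides.

Still open, on these data alone, is whether the hydroxymethyl group or the place of the ring substituent carries that gap. A 4-methylpiperidin-1-yl amide would separate the two, and a piperidine bearing a carboxylic acid or an amine would extend the comparison.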